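Adding a Pyridylmethyl Arm to an Inactive Amide

A few compounds are considered here, and "the series" means these few. Any claim that something is new, unique, unknown or untested is made for them only; others in the source may bear on it.

Measured so far in a functional assay on CHO-RD-HGA16 cells for agonist activity at Orexin/Hypocretin receptor type 1 (Homo sapiens), read by fluorescence and calcium flux, with a stated time of 30 min; on this read-out lower numbers stand for an effect already at smaller amounts and higher numbers for an effect only at larger amounts of compound:
- compound 1 `COc1ccc(-c2cccc(C(=O)N(C)C)c2)cc1S(=O)(=O)Nc1cccc(N2CCN(C(=O)c3cccc(C)c3)CC2)c1` gives > 10000 nM, which is a limit of the assay and not a number.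
- compound 2 `COc1ccc(-c2cccc(C(=O)NCCN(C)C)c2)cc1S(=O)(=O)Nc1cccc(NCCNC(=O)c2cccc(C)c2)c1` gives > 10000 nM, again a limit.
- compound 3 `COc1ccc(-c2cccc(C(=O)N(C)C)c2)cc1C(=O)Nc1cccc(NCCNC(=O)c2cccc(C)c2)c1` gives > 10000 nM, also a limit.

Compound 3 therefore stands where every other compound stands, at the limit of > 10000 nM in this assay, at which 3 of the 3 values shown sit, with no effect registered in the tested range. Compound 4 `COc1ccc(-c2cccc(C(=O)N(C)Cc3ccncc3)c2)cc1C(=O)Nc1cccc(NCCNC(=O)c2cccc(C)c2)c1` differs from compound 3 by pyridin-4-yl in place of hydrogen on a saturated chain carbon bound to an amide-type nitrogen. Within the data shown here, no measured pair shows what such a change does, and since only limits are known, no direction can be read from the data. The step that the limit leaves unreadable from compound 3 to compound 4 is expected to be none beyond the scatter. For compound 4 the estimated value in this assay is 15000 nM, within 3000 nM to 60000 nM, most likely reported once more only as a limit.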

Compound 4, half-maximal effective concentration: > 10000 nM
Compound 4 gave a limit, no number; the forecaster's own chance of this, stated with the estimate: 80%; the middle value does not contradict the limit.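

Compound 3 and compound 4 both sit at a limit of the assay rather than at a number, so no step between them can be read: the limit of > 10000 nM in this assay, at which 4 of the 4 values shown sit.

The compounds shown leave open whether pyridin-4-yl changes anything at all, and whether any change to the shared core gives a measurable effect.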